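Swapping Chloro for Methyl on a Triazole-Linked Phenyl

The source may report more compounds than this note shows. Statements on the series, on what has been measured and on what is new or still open speak of the compounds shown alone.

Four compounds built on a shared core, each carrying a triazole that holds a substituted phenyl ring, are compared in a functional assay on SW480 cells (Homo sapiens) for cytotoxicity, read by MTT assay, with a stated time of 4 days; a lower number here means a stronger inhibitor, a higher number a weaker inhibitor. Compound 1 `Cc1c(O)ccc2c1[C@H](Cn1cc(-c3ccc(F)cc3)nn1)[C@@]13CC(=O)[C@@](C)(CC[C@@H]21)C3` gives > 20000 nM, which is a limit of the assay and not a measured number. Compound 2 `C=C1C[C@]23C[C@@]1(O)CC[C@@H]2c1cccc(C)c1[C@@H]3Cn1cc(-c2ccc(Cl)cc2)nn1` likewise gives > 20000 nM, again a limit rather than a number. Compound 3 `C=C1C(=O)[C@]23C[C@@]1(O)CC[C@H]2c1ccc(O)c(C)c1[C@@H]3Cn1cc(-c2ccc(Cl)cc2)nn1` gives 280 nM. For the measured compounds named here, no pair of measured compounds differs in a single place, so no measured step is available; compound 2 stands only at the edge of what this assay can report, and it is not alone there, since (the limit of > 20000 nM in this assay, at which 2 of the 3 values shown sit).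

Compound 4 `C=C1C[C@]23C[C@@]1(O)CC[C@@H]2c1cccc(C)c1[C@@H]3Cn1cc(-c2ccc(C)cc2)nn1` is compound 2 with methyl in place of chloro on an aromatic carbon. Going by the values given here, nothing among the measured compounds isolates this change, so the expectation rests on the small size of the swap and on where compound 2 sits. The step from compound 2 to compound 4 is expected to be a number no higher from compound 2 to compound 4 (the limit leaves the size open), which is no change beyond the usual scatter. Compound 4 is therefore expected to give about 20000 nM, within a range from 8000 nM to 50000 nM, and the assay is expected most likely to report only a limit once more.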

Compound 4, half-maximal inhibitory concentration: > 20000 nM
Compound 4: a limit, no number (the forecaster's own chance of this, stated with the estimate: 80%); the middle value lies on the limit itself.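

In this assay compound 4 gives > 20000 nM, which is a limit and not a number. Compound 2 also stands at a limit, so the swap from 4-chlorophenyl to 4-methylphenyl between compound 2 and compound 4 cannot be read as a step: the limit of > 20000 nM in this assay, at which 3 of the 4 values shown sit.

The compounds shown leave open whether this swap changes anything on a compound that gives a measured number.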